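Trimming the Hydroxyethyl Arm: Compound 3 to Compound 4

The source may report more compounds than this note shows. Statements on the series, on what has been measured and on what is new or still open speak of the compounds shown alone.

Of the compounds shown here, three built on one shared core have been tested in an assay on isolated protein for binding affinity to adenosine receptor A1 (Bos taurus); on this read-out higher numbers stand for weaker inhibition and lower numbers for stronger inhibition. Compound 1 `CCCCCCNc1nc(-c2ccccc2)nc2c1nnn2Cc1ccccc1Cl` gives 31000000 nM, compound 2 `c1ccc(Cn2nnc3c(NC4CC4)nc(-c4ccccc4)nc32)cc1` gives 11000000 nM, and compound 3 `OCCNc1nc(-c2ccccc2)nc2c1nnn2Cc1ccccc1F` gives 54000000 nM. Compound 3 thus carries the highest of the three numbers; its gap to compound 1 lies within the usual scatter, while its gap to compound 2 lies beyond it. Compound 4 `CNc1nc(-c2ccccc2)nc2c1nnn2Cc1ccccc1F` differs from compound 3 in a single place: hydrogen in place of hydroxymethyl on a saturated chain carbon bound to a nitrogen on an aromatic ring. Among the measured compounds shown here, no pair of measured compounds differs in just one place, so nothing directly calibrates this change, and only a small step is expected. For compound 4 the step from compound 3 is expected to be a 1.8-fold lower number from compound 3 to compound 4 (0.26 log units; within the scatter), toward a somewhat lower number. The estimate for compound 4 is 30000000 nM, expected to fall between 8000000 nM and 120000000 nM.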

Compound 4, inhibition constant: 25000000 nM
Compound 4: middle estimate off by 1.2-fold (0.08 log units), on the high side; low and high end bracket the measured number.
By their numbers in this assay, from the lowest: compound 2; then compounds 4, 1 and 3 (each within the scatter of the next, the first and the last beyond it).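

In this assay, among the compounds shown here, going from (2-hydroxyethyl)amino to methylamino gives a 2.2-fold lower number from compound 3 to compound 4 (0.33 log units; beyond the scatter) and provides the first one-place comparison on this core. The step is modest but lies beyond the scatter, so this position responds measurably to removing hydroxymethyl, and the lower number does not depend on keeping that group. Nothing measured here explains the shift.

Going by these compounds, whether an ethyl chain, or a chain ending in an amine or a carboxylic acid, would move the number further remains open. Also open, on these data alone, is whether the same step would appear with other groups elsewhere on the core.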